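This account rests on a few compounds, and the source may have more. Where it says the series, first, only, none or still open, it means among the compounds named here.

Within the data shown here, in a functional assay on HeLa cells (Homo sapiens) for antiproliferative activity, read by spectrophotometry, with a stated time of 2 days (on this read-out higher numbers stand for weaker inhibition of growth and lower numbers for stronger inhibition of growth), compound 3 `Cc1cc(Cl)ccc1Nc1ncc(C(F)(F)F)c(N2Cc3cccc(N(C)S(C)(=O)=O)c3C2)n1` gives 17400 nM, the only actual number among the three compounds measured. Compound 1 `CN(c1cccc2c1CN(c1nc(Nc3ccc(C(F)(F)F)cc3)ncc1C(F)(F)F)C2)S(C)(=O)=O` gives > 30000 nM, which is a limit of the assay. Compound 2 `Cc1cc(C)cc(Nc2ncc(C(F)(F)F)c(N3Cc4cccc(N(C)S(C)(=O)=O)c4C3)n2)c1` gives > 30000 nM, likewise a limit. The step now followed leads to compound 4 `CN(c1cccc2c1CN(c1nc(Nc3ccc(Cl)c(C(F)(F)F)c3)ncc1C(F)(F)F)C2)S(C)(=O)=O`, with 4-chloro-3-(trifluoromethyl)phenyl in place of 4-chloro-2-methylphenyl on a nitrogen on an aromatic ring. The measured steps that bear on it change this same group. They are an at least 1.7-fold lower number from compound 1 to compound 3 (0.23 log units; that floor lies within the scatter) and an at least 1.7-fold lower number from compound 2 to compound 3 (0.23 log units; that floor lies within the scatter), both floors within the scatter, while the third is a step that the two limits leave unreadable from compound 1 to compound 2. These steps give no firm size for a change at this place. A trifluoromethyl also sits on this phenyl in compound 1, and compound 1 stays at > 30000 nM, so a result at the limit would not be surprising. No step beyond the scatter is therefore expected, and the estimate is a 1.3-fold higher number from compound 3 to compound 4 (0.10 log units; within the scatter). For compound 4 the expected value is 22000 nM, with an estimated range from 8000 nM to 45000 nM.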

Compound 4, concentration for 50% growth inhibition: 11100 nM
Compound 4: the middle estimate sits 2.0-fold (0.30 log units) above what was measured; the measured number falls inside the stated range.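

In this assay, a trifluoromethyl on this phenyl does not by itself hold a compound at the limit, for with a chloro also on the ring the result is readable: an at least 2.7-fold lower number from compound 1 to compound 4 (0.43 log units; beyond the scatter), and an at least 2.7-fold lower number from compound 2 to compound 4 (0.43 log units; beyond the scatter). Both steps give only a floor and not a full size because their starting values are limits of the assay: the limit of > 30000 nM in this assay, at which 2 of the 4 values shown sit. The swap of 4-chloro-2-methylphenyl for 4-chloro-3-(trifluoromethyl)phenyl, however, separates nothing, as a 1.6-fold lower number from compound 3 to compound 4 (0.20 log units; within the scatter) leaves the two compounds indistinguishable, so the two chloro-bearing compounds are the two with actual numbers, and none of the four goes against that.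

The compounds shown leave open whether a plain 4-chlorophenyl would suffice without the methyl or trifluoromethyl. Going by these compounds, how a nitrile, an amine or a carboxylic acid on this phenyl would read also remains open.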